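Piperidin-1-yl for Pyrrolidin-1-yl on Compound 2

This account rests on a few compounds, and the source may have more. Where it says the series, first, only, none or still open, it means among the compounds named here.

Within the data shown here, in an assay on HeLa cells for inhibition of sphingosine-1-phosphate transporter SPNS2 (Mus musculus), read by LC-MS, tested at 2 uM (a lower number here means less inhibition, a higher number more inhibition at the concentration tested (going by the name of the read-out)), compound 2 `CCCCCCCCCCc1ccc(-c2noc(CC(O)CN3CCCC3)n2)cc1` gives 21%, the lowest of the two numbers so far. Among the measured compounds shown here, compound 1 `CCCCCCCCCCc1ccc(-c2noc(C3CCNC3)n2)cc1` gives 26% in this assay, and the single known step, a number 5 percentage points lower from compound 1 to compound 2 (within the scatter), stays within the scatter. Compound 3 `CCCCCCCCCCc1ccc(-c2noc(CC(O)CN3CCCCC3)n2)cc1` differs from compound 2 by piperidin-1-yl in place of pyrrolidin-1-yl on a saturated chain carbon, two bonds along the chain from an oxygen on a saturated carbon. For the measured compounds named here, no measured step bears on this change, and the one step available was flat, so the expected step of a number 3 percentage points higher from compound 2 to compound 3 (within the scatter) is estimated to remain within the scatter. Compound 3 is therefore estimated at 24%, with a range from 10% to 40%.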

Compound 3, a percentage reported as inhibition, at one concentration (the size of the read-out at that concentration, not a potency): 2%
For compound 3 the middle estimate is 22 percentage points above the measured one, and the stated range ends above it.
By their numbers in this assay, from the lowest: compound 3; then compounds 2 and 1 (each within the scatter of the next).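

In this assay, among these compounds, the ring at this place on the chain matters: piperidin-1-yl in place of pyrrolidin-1-yl brings the first change beyond the scatter (a number 19 percentage points lower from compound 2 to compound 3 (beyond the scatter)). The 2-hydroxy-3-(piperidin-1-yl)propyl group also parts from pyrrolidin-3-yl (a number 24 percentage points lower from compound 1 to compound 3 (beyond the scatter)), which the 2-hydroxy-3-(pyrrolidin-1-yl)propyl group did not do. No evidence is available to account for this difference. Still open, as far as these compounds go, is how an azetidin-1-yl or morpholin-4-yl group would read at the same place, and whether the piperidin-1-yl result would hold with a longer chain in place of the 2-hydroxypropyl link.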